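The compounds below may be only part of what the source reports. "The series", "measured", "known", "first", "only" and "open" are said of these compounds alone.

Values in a functional assay on KB 3-1 cells (Homo sapiens) for cytotoxicity, read by MTT assay, with a stated time of 68 h (a lower number here means a stronger inhibitor, a higher number a weaker inhibitor), so far:
Compound 1 `O=C(Nc1cccc(-c2cccc(F)c2)c1)C(Cl)Cl` gives > 50000 nM as a limit
Compound 2 `COc1ccc(-c2cccc(NC(=O)C(Cl)Cl)c2)cc1` gives > 50000 nM as a limit
Compound 3 `Cc1ccc(-c2cccc(NC(=O)C(Cl)Cl)c2)cc1` gives > 50000 nM as a limit

Compound 3 therefore offers no number to start from, and the series as a whole stands at the limit of > 50000 nM in this assay, at which 3 of the 3 values shown sit, without exception. Compound 4 `O=C(Nc1cccc(-c2ccc(C(F)(F)F)cc2)c1)C(Cl)Cl` carries trifluoromethyl in place of methyl on an aromatic carbon, para to a large group, with trifluoromethyl in place of methyl on an aromatic carbon as the count. For the measured compounds named here, the only measured step bearing on this is a step that the two limits leave unreadable from compound 2 to compound 3 and it gives no size to carry over. In this assay the expected step of a number no higher from compound 3 to compound 4 (the limit leaves the size open) is none beyond the scatter, with no direction expected, and another limit is the likeliest report. The estimated value for compound 4 is 50000 nM with an expected range from 20000 nM to 80000 nM in this estimate.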

Compound 4, half-maximal inhibitory concentration: > 50000 nM
Compound 4: no number, only a limit (the forecaster's own chance of this, stated with the estimate: 85%); the middle value lies on the limit itself.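

In this assay, for the compounds shown here, compound 4 gives > 50000 nM, a limit, and no step to it from compound 2 or compound 3 can be read. Whether any of these groups on the shared core alters cytotoxicity stays open, with every compound shown at one limit: the limit of > 50000 nM in this assay, at which 4 of the 4 values shown sit.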